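Replacing the 4-nitrophenyl group of compound 3

The compounds below may be only part of what the source reports. "The series", "measured", "known", "first", "only" and "open" are said of these compounds alone.

Measured in a functional assay on SW-620 cells (Homo sapiens) for cytotoxicity, read by sulforhodamine B assay, with a stated time of 48 h; a higher number here means a weaker inhibitor, a lower number a stronger inhibitor:
Compound 1 `COc1ccc(C2=NO[C@]3(C2)C(=O)O[C@@H]2[C@H]3CC[C@H](C)[C@]3(O)C=CC(=O)[C@@]23C)cc1`: 41000 nM
Compound 2 `C[C@H]1CC[C@@H]2[C@@H](OC(=O)[C@]23CC(c2ccc(O)cc2)=NO3)[C@]2(C)C(=O)C=C[C@@]12O`: 89000 nM
Compound 3 `C[C@H]1CC[C@@H]2[C@@H](OC(=O)[C@]23CC(c2ccc([N+](=O)[O-])cc2)=NO3)[C@]2(C)C(=O)C=C[C@@]12O`: 9000 nM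

Of the three, compound 3 has the lowest number, 9000 nM. Compound 4 `COc1cc(C2=NO[C@]3(C2)C(=O)O[C@@H]2[C@H]3CC[C@H](C)[C@]3(O)C=CC(=O)[C@@]23C)ccc1O` carries 4-hydroxy-3-methoxyphenyl in place of the 4-nitrophenyl of compound 3: 4-hydroxy-3-methoxyphenyl in place of 4-nitrophenyl on a carbon with a double bond to nitrogen. Within the data shown here, two measured steps bear on this change: a 4.6-fold lower number from compound 1 to compound 3 (0.66 log units; beyond the scatter), nitro in place of methoxy, and a 9.9-fold lower number from compound 2 to compound 3 (1.00 log units; beyond the scatter), nitro in place of hydroxy. Compound 4 has both hydroxy and methoxy and lacks nitro, so in this assay a step of similar size is expected, running the opposite way and beyond the scatter. The expected step is a 6.7-fold higher number from compound 3 to compound 4 (0.82 log units; beyond the scatter). For compound 4 the estimated value is 60000 nM, with an expected range of 25000 nM to 140000 nM.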

Compound 4, half-maximal inhibitory concentration: 88000 nM
Compound 4: the middle estimate sits 1.5-fold (0.17 log units) below what was measured; the measured number falls inside the stated range.
By their numbers in this assay, from the lowest: compound 3; then compound 1; then compounds 4 and 2 (each within the scatter of the next).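

In this assay, the methoxy added to the hydroxyphenyl ring makes no difference, a 1.0-fold lower number from compound 2 to compound 4 (0.00 log units; within the scatter), whereas a hydroxy added to the methoxyphenyl ring does, a 2.1-fold higher number from compound 1 to compound 4 (0.33 log units; beyond the scatter). Among these compounds, then, the hydroxy rather than the methoxy goes with the higher number, and combining the two groups gives no further rise over hydroxy alone, leaving the full loss on removing 4-nitrophenyl at a 9.8-fold higher number from compound 3 to compound 4 (0.99 log units; beyond the scatter). Nothing available explains why these groups differ in this way.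

From the compounds shown here alone, whether the lower number belongs to nitro alone remains open. An amine or a nitrile on the aromatic ring would test this.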